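The compounds below may be only part of what the source reports. "The series", "measured", "known", "first", "only" and "open" are said of these compounds alone.

Measured compounds:
compound 1 `COc1cc(NC(=O)Nc2cc(Nc3ccc(C)c(C)c3)ncn2)cc(OC)c1` — 29.5%
compound 2 `COc1cc(NC(=O)Nc2cc(Nc3cc(I)ccc3OC)ncn2)cc(OC)c1` — 55%
compound 3 `COc1cc(NC(=O)Nc2cc(Nc3ccc(Br)cc3OC)ncn2)cc(OC)c1` — 36.1%

In a functional assay on NCI-H520 cells (Homo sapiens) for inhibition, read by MTT assay, with a stated time of 48 h, tested at 10 uM (on this read-out lower numbers stand for less inhibition and higher numbers for more inhibition at the one concentration tested (going by the name of the read-out)), compound 3 gives 36.1%, the second highest of the three numbers. Compound 1 is nearest: the step of a number 6.6 percentage points higher from compound 1 to compound 3 (within the scatter) lies within the scatter, so the two cannot be ordered. Compound 2 is furthest, with the step of a number 18.9 percentage points lower from compound 2 to compound 3 (beyond the scatter) beyond the scatter.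

Compound 4 `COc1cc(NC(=O)Nc2cc(Nc3ccc(OC)c(I)c3)ncn2)cc(OC)c1` has not yet been measured in this assay. Compared with compound 3 the change is 3-iodo-4-methoxyphenyl in place of 4-bromo-2-methoxyphenyl on a nitrogen on an aromatic ring.

Among the measured compounds shown here, two measured steps bear on this. For the measured compounds named here, the step of a number 25.5 percentage points higher from compound 1 to compound 2 (beyond the scatter) and the step of a number 18.9 percentage points lower from compound 2 to compound 3 (beyond the scatter) both show that the only iodine-bearing group in the set, 5-iodo-2-methoxyphenyl, gave the higher number, while 4-bromo-2-methoxyphenyl and 3,4-dimethylphenyl gave numbers that do not separate from one another. Compound 4 carries iodine and a methoxy group as well, though on the ring as 3-iodo-4-methoxyphenyl, for which no direct comparison exists. A modest rise from compound 3 is therefore expected, smaller and less certain than the step seen to compound 2. The step of a number 8.9 percentage points higher from compound 3 to compound 4 (within the scatter) is the estimated outcome. For compound 4 the expected value is 45%, with a range from 25% to 65%.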

Compound 4, a percentage reported as inhibition, at one concentration (the size of the read-out at that concentration, not a potency): 46.5%
The estimate for compound 4 lay 1.5 percentage points below the measured number; the measured number falls inside the stated range.
By their numbers in this assay, from the lowest: compounds 1 and 3 (each within the scatter of the next); then compounds 4 and 2 (each within the scatter of the next).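

In this assay the change on the nitrogen gives a number 10.4 percentage points higher from compound 3 to compound 4 (beyond the scatter), and the comparison with the dimethyl compound gives a number 17 percentage points higher from compound 1 to compound 4 (beyond the scatter), so a second iodine-bearing group now stands clear of both non-iodinated groups. Against the first iodine-bearing group the result is a number 8.5 percentage points lower from compound 2 to compound 4 (within the scatter), so 3-iodo-4-methoxyphenyl and 5-iodo-2-methoxyphenyl cannot be ordered, and in these four compounds the two arrangements of iodine and methoxy on the ring give no separable difference, while the methoxy group in compound 3 does not by itself go with the higher numbers. No measurement accompanies these numbers that would account for the link with iodine, which remains an association across four compounds.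

Still open, going by these compounds, is whether iodine itself or its place on the ring goes with the rise: 3-bromo-4-methoxyphenyl or plain 3-iodophenyl on the same nitrogen would separate the two. Also open, on these data alone, is how a quite different group at this position, such as a morpholine or a carboxylic acid, would read out, and what changes elsewhere on the shared core would do.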